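Removing a Chloro Group from a Weakly Cytotoxic Sulfonamide

The source may hold more compounds than are shown below. What is called first, only, known or untested is meant among the compounds shown, and "the series" means these compounds.

Of the compounds shown here, two have been tested in an ADME assay on HCT-116 cells (Homo sapiens) for cytotoxicity, read by CellTiter-Glo, with a stated time of 72 h; on this read-out higher numbers stand for weaker inhibition and lower numbers for stronger inhibition. Compound 1 `CCc1ccc(S(=O)(=O)N2CCC(N3CCC(C)CC3)CC2)cc1` shows no measurable effect: in this assay compound 1 reaches only > 5000 nM, which is a limit of the measurement and not a number. Compound 2 `CC1CCN(C2CCN(S(=O)(=O)c3cccc(-c4ccc(Cl)cc4)c3)CC2)CC1` behaves the same way: in this assay compound 2 also gives only > 5000 nM, again a limit rather than a number. Both results sit at the same boundary, as the limit of > 5000 nM in this assay, at which 2 of the 2 values shown sit, records, so compound 2 cannot be placed above or below compound 1.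

Compound 3 `CC1CCN(C2CCN(S(=O)(=O)c3cccc(-c4ccccc4)c3)CC2)CC1` is the next to be measured. It differs from compound 2 in one place: hydrogen in place of chloro on an aromatic carbon. The chloro that leaves sits on an aromatic carbon of a six-membered aromatic ring of carbon only, para to a large group; cut one bond further out, the change reads 4-chlorophenyl to phenyl.

Within the data shown here, since compound 2 rests at the limit, no measured step sets a direction. The expected step from compound 2 to compound 3 a step that the limit leaves unreadable from compound 2 to compound 3 is none beyond the scatter, with compound 3 most likely to stay at the same limit. The estimate for compound 3 in this assay is 9000 nM, in a range from 4000 nM to 30000 nM.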

Compound 3, half-maximal inhibitory concentration: > 5000 nM
Compound 3 gave a limit, no number; the forecaster's own chance of this, stated with the estimate: 85%; the middle value does not contradict the limit.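

Replacing chloro with hydrogen gives no readable step between compound 2 and compound 3, because neither yields a number in this assay: the limit of > 5000 nM in this assay, at which 3 of the 3 values shown sit.

The compounds shown leave open how strongly compound 1, compound 2 and compound 3 act on these cells, and whether changing 4-chlorophenyl to phenyl alters that effect at all.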